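Trimming the Long Ester Chain of Compound 2

The source may report more compounds than this note shows. Statements on the series, on what has been measured and on what is new or still open speak of the compounds shown alone.

In a toxicity assay on MRC5 cells (Homo sapiens) for inhibition, read by MTT assay, with a stated time of 72 h (on this read-out higher numbers stand for weaker inhibition and lower numbers for stronger inhibition), compound 1 `CCCC(=O)OCCc1ccc(O)c(O)c1` gives 71500 nM. As far as these compounds go, compound 2 `CCCCCCCCCCCCCC(=O)OCCc1ccc(O)c(O)c1` gives only a limit of the assay, > 50000 nM, and no number, so its exact place remains unknown. Compound 3 `CCCCCCCCCCCCC(=O)OCCc1ccc(O)c(O)c1` departs from compound 2 by hydrogen in place of methyl on a saturated chain carbon, ten or more bonds along the chain from a carbonyl carbon. No step beyond the scatter is expected in this assay, the estimated change being a step that the limit leaves unreadable from compound 2 to compound 3. For compound 3 the estimate is 60000 nM, with an expected range of 28000 nM to 110000 nM.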

Compound 3, half-maximal inhibitory concentration: 13200 nM
Compound 3: the middle estimate sits 4.5-fold (0.66 log units) above what was measured, outside the stated range (below it).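

The earlier compounds shown here gave no step at this place, but in this assay, hydrogen in place of methyl on a saturated chain carbon, ten or more bonds along the chain from a carbonyl carbon, gives an at least 3.7-fold lower number from compound 2 to compound 3 (0.57 log units; beyond the scatter). So a change this far along the chain can move the number beyond the scatter, and a lower number here means stronger inhibition. That size is only a bound, set by a limit of the assay: the limit of > 50000 nM in this assay, at which 1 of the 3 values shown sits.

As far as these compounds go, how large the true step is stays open. So does what a longer chain, or an amine or a carboxylic acid at this place, would do.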